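Swapping the Sulfonyl Aryl Group: What Compound 3 May Show

This account rests on a few compounds, and the source may have more. Where it says the series, first, only, none or still open, it means among the compounds named here.

Of the compounds shown here, two built on one shared core have been measured in an assay on isolated protein for binding affinity to histamine H2 receptor (Homo sapiens); on this read-out lower numbers stand for stronger inhibition and higher numbers for weaker inhibition. Compound 1, `O=C(c1ccc(OCCCN2CC[C@H](NS(=O)(=O)c3ccccc3F)C2)cc1)C1CC1`, gives 1550 nM in this assay. Compound 2, `O=C(c1ccc(OCCCN2CC[C@H](NS(=O)(=O)c3cccc(Cl)c3)C2)cc1)C1CC1`, gives 700 nM in this assay. Within the data shown here, the single measured step between them is a 2.2-fold lower number from compound 1 to compound 2 (0.35 log units; beyond the scatter). Among the measured compounds shown here, compound 2 therefore holds the lower of the two numbers, with compound 1 the only neighbour and standing at the higher figure.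

The unmeasured compound 3, `CCc1ccc(S(=O)(=O)N[C@H]2CCN(CCCOc3ccc(C(=O)C4CC4)cc3)C2)cc1`, differs from compound 2 by 4-ethylphenyl in place of 3-chlorophenyl on a sulfonyl sulfur. For the measured compounds named here, no measured step exchanges a chlorine-bearing phenyl for an ethyl-bearing one, so the one step at hand, a 2.2-fold lower number from compound 1 to compound 2 (0.35 log units; beyond the scatter), bears only loosely on this change: it shows that trading one substituted phenyl on the sulfonyl sulfur for another can shift the number by a modest amount, but it gives no indication of direction for 4-ethylphenyl. The expected step from compound 2 to compound 3 in this assay is therefore a 1.1-fold higher number from compound 2 to compound 3 (0.06 log units; within the scatter), a change not beyond the scatter. Compound 3 is estimated to give 800 nM in this assay, with a range from 300 nM to 2200 nM.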

Compound 3, inhibition constant: 330 nM
Beside the measured number, compound 3's estimate is 2.4-fold (0.38 log units) above it, within the range that was stated.
By their numbers in this assay, from the lowest: compound 3; then compound 2; then compound 1.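

In this assay the move to 4-ethylphenyl gives a 2.1-fold lower number from compound 2 to compound 3 (0.33 log units; beyond the scatter) and so shows that a phenyl ring without a halogen can sit on this sulfonyl sulfur and still lower the number, something the two halogen-bearing rings could not show. The change from the 2-fluorophenyl ring gives a 4.7-fold lower number from compound 1 to compound 3 (0.67 log units; beyond the scatter) and widens the span seen at this one position, placing compound 3 lowest of the three with both of its steps beyond the scatter. Nothing available bears on why the rings fall in this order.

The 3-chlorophenyl and 4-ethylphenyl rings differ in both the substituent and the place it occupies on the ring, so these compounds cannot separate the effect of the ethyl group from the effect of where it sits. Also open, from the compounds shown here alone, are the results for 3-ethylphenyl and 4-chlorophenyl, which would separate those two changes, and whether a longer chain such as 4-propylphenyl, or an amine on the ring, would continue or reverse the step.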